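A 2-Hydroxyethyl Chain Becomes 2-Methoxyethyl

A few compounds are considered here, and "the series" means these few. Any claim that something is new, unique, unknown or untested is made for them only; others in the source may bear on it.

Of the compounds shown here, two have so far been measured in a physicochemical assay for solubility, using the shake flask method, in phosphate buffer, with a stated time of 24 h, at pH 6.8 (on this read-out lower numbers stand for lower solubility and higher numbers for higher solubility), and they lie well apart. Compound 1 `COc1cc(/C=C/C(=O)/C=C(/C=C/c2ccc(O)c(OC)c2)NCCO)ccc1O` gives 11800 nM and holds the lower number of the pair. Compound 2 `COc1cc(/C=C/C2=CC(=O)CC(c3ccc(O)c(OC)c3)N2CCCO)ccc1O` gives 62900 nM and this higher number lies beyond the usual scatter. Among the measured compounds shown here, no measured pair here differs in one place only, so the data hold no direct precedent for a single change.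

Compound 3 `COCCNC(=C\C(=O)/C=C/c1ccc(O)c(OC)c1)/C=C/c1ccc(O)c(OC)c1` has not yet been measured. It departs from compound 1 by one change (methyl in place of hydrogen on an oxygen on a saturated carbon) that puts methyl in place of hydrogen on an oxygen on a saturated carbon and so turns 2-hydroxyethyl into 2-methoxyethyl. In this assay a step no larger than the scatter is expected, leaning slightly downward if it shows at all. This expectation rests only on the size of the change and on compound 1 at 11800 nM as the starting point. The estimated step of a 1.2-fold lower number from compound 1 to compound 3 (0.07 log units; within the scatter) stays inside the usual scatter. For compound 3 the estimate is 10000 nM with an expected range of 4000 nM to 25000 nM across repeat measurements.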

Compound 3, solubility: 12700 nM
For compound 3 the middle estimate is 1.3-fold (0.10 log units) below the measured one; measured number inside the range.
By their numbers in this assay, from the lowest: compounds 1 and 3 (each within the scatter of the next); then compound 2.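

In this assay, methyl in place of hydrogen on an oxygen on a saturated carbon gives a 1.1-fold higher number from compound 1 to compound 3 (0.03 log units; within the scatter), so the two compounds cannot be told apart on this read-out. Among the compounds shown here, this is the first measured pair in the set that differs in one place only, and it shows that turning 2-hydroxyethyl into 2-methoxyethyl on the core of compound 1 leaves the number within the usual scatter, which the earlier compounds could not show. Nothing measured alongside these numbers offers an account of this result.

The compounds shown leave open whether a larger replacement for the hydroxy, such as an amine, a carboxylic acid or a longer chain carrying a methoxy, would also leave the number within the scatter on this core. Compound 2 differs from compound 1 in more than one place, so it cannot say whether the same change would give a similar step on its core, and that question would need a 2-methoxy-bearing partner for compound 2 measured in this assay.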